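The source may hold more compounds than are shown below. What is called first, only, known or untested is meant among the compounds shown, and "the series" means these compounds.

Measured compounds:
compound 1, `Nc1cc(-c2nc(C(c3ccc(F)cc3)c3ccc(F)cc3)sc2CC(=O)O)cc(F)n1`: 1400 nM
compound 2, `O=C(O)Cc1sc(C(c2ccc(F)cc2)c2ccc(F)cc2)nc1-c1ccnc(N2CCCC2)c1`: > 100000 nM

In an in vitro functional assay on HEK285-7 cells for antagonist activity at prostaglandin D2 receptor 2 (Homo sapiens), read by BRET and beta-arrestin recruitment (a higher number here means a weaker inhibitor, a lower number a stronger inhibitor), compound 2 gives > 100000 nM, which is a limit of the assay and not a number (the limit of > 100000 nM in this assay, at which 1 of the 2 values shown sits). Compound 3, `Cc1cc(-c2nc(C(c3ccc(F)cc3)c3ccc(F)cc3)sc2CC(=O)O)cnc1N`, has not yet been measured in this assay. It differs from compound 2 by 6-amino-5-methylpyridin-3-yl in place of 2-(pyrrolidin-1-yl)pyridin-4-yl on an aromatic carbon. Among the measured compounds shown here, one measured step bears on this position: an at least 71-fold higher number from compound 1 to compound 2 (1.85 log units; beyond the scatter), where compound 1 carries an amino-substituted pyridinyl and compound 2 a pyrrolidinyl-substituted one. Compound 3 again carries an amino group on its pyridinyl, and its value in this assay is expected to return toward the range of compound 1. For compound 3 a step of an at least 33-fold lower number from compound 2 to compound 3 (1.52 log units; beyond the scatter) in this assay is therefore expected. Compound 2 stands only at a limit, so the size of that step cannot be set closely. Compound 3 is estimated at 3000 nM, with a range from 500 nM to 30000 nM.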

Compound 3, half-maximal inhibitory concentration: > 100000 nM
Compound 3 gave a limit, no number; the forecaster's own chance of this, stated with the estimate: 20%; middle value at least 33-fold (1.52 log units) from the limit.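

In this assay, 6-amino-5-methylpyridin-3-yl in place of 2-amino-6-fluoropyridin-4-yl gives an at least 71-fold higher number from compound 1 to compound 3 (1.85 log units; beyond the scatter), so an amino group on the pyridinyl is not enough at this position to keep a measurable value. The earlier step could not separate the amino group from the rest of the change, whereas compound 3 keeps a hydrogen-bond donor on the pyridinyl and still ends at a limit, leaving compound 1 the only one of the three with a number. Compound 2 and compound 3 both stand at limits, and the step between them cannot be read: the limit of > 100000 nM in this assay, at which 2 of the 3 values shown sit.

Still open, as far as these compounds go, is which part of the change counts: the methyl group against the fluorine, or the different arrangement of amino group and ring nitrogen on the pyridinyl. Also open, from the compounds shown here alone, is how a methoxy group or a chlorine atom in place of the fluorine of compound 1 would read.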